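The source may hold more compounds than are shown below. What is called first, only, known or untested is meant among the compounds shown, and "the series" means these compounds.

In a functional assay on MCF7 cells (Homo sapiens) for inhibition, read by fluorescence, with a stated time of 72 h (a lower number here means a stronger inhibitor, a higher number a weaker inhibitor), compound 1 (`CCCn1cnc2c(NC(=N)N)nc(N)nc21`) gives 36500 nM. Compound 2 (`CC[C@@H](N)COc1nc(NC(=N)N)c2ncn(C(C)C)c2n1`) gives > 100000 nM, which is a limit of the assay and not a number. Compound 3 (`CC[C@H](CO)Nc1nc(NC(=N)N)c2ncn(C(C)C)c2n1`) gives 4500 nM, the lower of the two actual numbers and beyond the scatter from compound 1.

Compound 4 (`CC(C)n1cnc2c(NC(=N)N)nc(NC3CC3)nc21`) has cyclopropyl in place of 1-(hydroxymethyl)propyl on a nitrogen on an aromatic ring. Among the compounds with values here, one measured step bears on this: an at least 22-fold lower number from compound 2 to compound 3 (1.34 log units; beyond the scatter). It is large, starts from a limit and brought in the group that now leaves. Compound 4 keeps the nitrogen link, so only part of that size seems likely. Expected in this assay is a smaller step towards a higher number, a 3.1-fold higher number from compound 3 to compound 4 (0.49 log units; beyond the scatter). For compound 4 the estimated value is 14000 nM, with an expected range of 4000 nM to 50000 nM.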

Compound 4, half-maximal inhibitory concentration: 5400 nM
Compound 4: the middle estimate sits 2.6-fold (0.41 log units) above what was measured, and the stated range covers the measured number.
By their numbers in this assay, from the lowest: compounds 3 and 4 (each within the scatter of the next); then compound 1. At a limit, above all of these: compound 2.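

In this assay, the step at this nitrogen is a 1.2-fold higher number from compound 3 to compound 4 (0.08 log units; within the scatter), so the hydrogen-bond donor, hydrogen-bond acceptor and defined stereocentre of 1-(hydroxymethyl)propyl are not needed to hold this level. The second step, an at least 18-fold lower number from compound 2 to compound 4 (1.26 log units; beyond the scatter), starts from a limit. It changes the link and the side chain together, so the link's own share stays unseparated.

On these data alone, what a benzyl group or a longer alkyl chain on this nitrogen would give stays open. So does the outcome of swapping the link with the side chain held constant.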